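Working notes: from compound 2 to compound 3

The source may report more compounds than this note shows. Statements on the series, on what has been measured and on what is new or still open speak of the compounds shown alone.

Measured in a functional assay on MCF7 cells (Homo sapiens) for cytotoxicity, read by CellTiter-Glo, with a stated time of 5 days; a higher number here means a weaker inhibitor, a lower number a stronger inhibitor:
compound 1 `CC/C(=C(/c1csc(/C=C/C(=O)O)c1)c1ccc2[nH]ncc2c1)c1ccccc1`: 2900 nM
compound 2 `CC/C(=C(/c1ccc(/C=C/C(=O)O)cc1)c1ccc2[nH]ncc2c1)c1ccc(Cl)cc1`: 15 nM

Going by the values given here, compound 2 has the lowest number of the two measured; its only neighbour is compound 1, and the gap between them lies beyond the scatter. Compound 3 `CC/C(=C(/c1ccc(/C=C/C(=O)O)cc1)c1ccc2[nH]ncc2c1)c1ccncc1C` is not yet measured. It differs from compound 2 in one place: 3-methylpyridin-4-yl in place of 4-chlorophenyl on a double-bonded chain carbon bound to a double-bonded chain carbon and a saturated chain carbon. Among the compounds with values here, no measured pair shows this change, so the expected step from compound 2 to compound 3 in this assay is a modest one toward a higher number, near the edge of the scatter. Compound 3 is expected at 40 nM, within 10 nM to 200 nM. The step this implies is estimated at a 2.7-fold higher number from compound 2 to compound 3 (0.43 log units; beyond the scatter).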

Compound 3, half-maximal inhibitory concentration: 16 nM
Beside the measured number, compound 3's estimate is 2.5-fold (0.40 log units) above it; measured number inside the range.
By their numbers in this assay, from the lowest: compounds 2 and 3 (each within the scatter of the next); then compound 1.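

In this assay, 3-methylpyridin-4-yl in place of 4-chlorophenyl on a double-bonded chain carbon bound to a double-bonded chain carbon and a saturated chain carbon gives a 1.1-fold higher number from compound 2 to compound 3 (0.03 log units; within the scatter), the first step measured at this position. This place therefore accepts an aromatic ring with a hetero atom and a hydrogen-bond acceptor, with no loss beyond the scatter. Nothing available explains this result.

The compounds shown do not separate the methyl from the ring nitrogen, and pyridin-4-yl without the methyl would divide the two. From the compounds shown here alone, how far this place accepts other groups, such as an amine, remains open.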